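The source may report more compounds than this note shows. Statements on the series, on what has been measured and on what is new or still open speak of the compounds shown alone.

Of the compounds shown here, three built on the same core have been measured in a physicochemical assay for lipophilicity, read by spectrophotometry, using the shake flask method, measured as octanol-water partition, with a stated time of 24 h; a higher number here means a more lipophilic compound, a lower number a more polar compound. Compound 1 `CN1CCN(CC(=O)Nc2nc3ccccc3[nH]2)CC1` gives 1.67. Compound 2 `O=C(CN1CCN(c2ccccc2F)CC1)Nc1nc2ccccc2[nH]1` gives 0.94, the lowest of the three numbers: a number 0.73 log units lower from compound 1 to compound 2 (beyond the scatter) and a number 1.00 log units higher from compound 2 to compound 3 (beyond the scatter), where compound 3 `O=C(CN1CCN(c2ccc([N+](=O)[O-])cc2)CC1)Nc1nc2ccccc2[nH]1` gives 1.94. Compound 4 `COc1ccccc1N1CCN(CC(=O)Nc2nc3ccccc3[nH]2)CC1` differs from compound 2 in one place: methoxy in place of fluoro on an aromatic carbon. Going by the values given here, no measured step exchanges one group on that aromatic ring for another; the steps seen so far put a 2-fluorophenyl or a 4-nitrophenyl in place of a methyl, so they bear on this change only loosely, showing that this part of the molecule can move the number modestly. Exchanging fluoro for methoxy is expected to shift the number in this assay little, so the estimated step is a number 0.14 log units lower from compound 2 to compound 4 (within the scatter), within the scatter. Compound 4 is therefore estimated at 0.8, between 0.4 and 1.3.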

Compound 4, partition coefficient: 0.97
For compound 4 the middle estimate is 0.17 log units below the measured one; the range from low to high includes it.
By their numbers in this assay, from the lowest: compounds 2 and 4 (each within the scatter of the next); then compounds 1 and 3 (each within the scatter of the next).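

In this assay, going by these compounds alone, this is the first exchange of one group for another on the aromatic ring itself, and it gives a number 0.03 log units higher from compound 2 to compound 4 (within the scatter), so at this carbon, ortho to a large group, fluoro and methoxy cannot be told apart. The 2-methoxyphenyl compound also keeps clear of the other two, with a number 0.70 log units lower from compound 1 to compound 4 (beyond the scatter) and a number 0.97 log units lower from compound 3 to compound 4 (beyond the scatter), much as the 2-fluorophenyl compound does. Nothing available bears on the cause of these steps.

As far as these compounds go, whether an amine or a carboxylic acid on this same carbon would give a similar number remains open. So does the number for a 4-methoxyphenyl or 4-fluorophenyl group, which would set either group alongside the 4-nitrophenyl of compound 3.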